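A few compounds are considered here, and "the series" means these few. Any claim that something is new, unique, unknown or untested is made for them only; others in the source may bear on it.

Compound 1 `COc1ccc(Oc2ccccc2-c2ccsc2S(=O)(=O)N2CCN(C(=O)Nc3ccc([N+](=O)[O-])cc3)CC2)cc1OC` was tested in a functional assay on RS4-11 cells (Homo sapiens) for inhibition, read by CCK-8 assay, with a stated time of 48 h; on this read-out lower numbers stand for stronger inhibition and higher numbers for weaker inhibition. In this assay compound 1 gives only a limit of the assay, > 50000 nM, rather than a number. Compound 3 `O=C(Nc1ccc([N+](=O)[O-])cc1)N1CCN(S(=O)(=O)c2sccc2-c2ccccc2Oc2ccc(O)c(O)c2)CC1` differs from compound 1 in one place: 3,4-dihydroxyphenyl in place of 3,4-dimethoxyphenyl on an oxygen on an aromatic ring. In this assay compound 3 gives 14300 nM, so the change produced an at least 3.4-fold lower number from compound 1 to compound 3 (0.54 log units; beyond the scatter); only the smallest possible size of this step is known, owing to the limit of > 50000 nM in this assay, at which 1 of the 3 values shown sits.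

Compound 2 `COc1ccc(Oc2ccc(C(C)C)cc2-c2ccsc2S(=O)(=O)NCCNC(=S)Nc2cc(C(F)(F)F)cc(C(F)(F)F)c2)cc1OC` carries the same 3,4-dimethoxyphenyl group on an oxygen on an aromatic ring, but the rest of the molecule differs from compound 1 in more than one place, and the difference between the two cores is not broken down here. In this assay compound 2 gives 5500 nM, the lower of the two numbers obtained so far, and its gap to compound 3 lies beyond the usual scatter.

Compound 4 `CC(C)c1ccc(Oc2ccc(O)c(O)c2)c(-c2ccsc2S(=O)(=O)NCCNC(=S)Nc2cc(C(F)(F)F)cc(C(F)(F)F)c2)c1` is the not yet measured partner of compound 2, made by the same change: 3,4-dihydroxyphenyl in place of 3,4-dimethoxyphenyl on an oxygen on an aromatic ring. For the measured compounds named here, the expectation that compound 4 gives a lower number than compound 2 rests on an at least 3.4-fold lower number from compound 1 to compound 3 (0.54 log units; beyond the scatter), the only earlier instance of this change, though that step is known only as a lower bound. Compound 4 is expected to give about 1800 nM in this assay. For compound 4 the estimated range runs from 700 nM to 5000 nM. For compound 4 this estimate amounts to an expected 3.1-fold lower number from compound 2 to compound 4 (0.49 log units; beyond the scatter), set beside the earlier step.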

Compound 4, half-maximal inhibitory concentration: 3700 nM
Estimate against measurement, compound 4: 2.1-fold (0.31 log units) below, and the stated range covers the measured number.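

On the core of compound 2, the change from 3,4-dimethoxyphenyl to 3,4-dihydroxyphenyl gives a 1.5-fold lower number from compound 2 to compound 4 (0.17 log units; within the scatter), so in this assay the two compounds cannot be told apart, and the clear step seen on the core of compound 1 is not shown to carry over to this second core. Nor is a real but small step on this core ruled out, and the two cores cannot be said to respond differently, as the comparison of the two steps shows: the same change on two cores in this assay, an at least 3.4-fold lower number (0.54 log units; beyond the scatter) from compound 1 to compound 3 and a 1.5-fold lower number (0.17 log units; within the scatter) from compound 2 to compound 4; the limit leaves it open whether they differ. Going by these compounds, compound 1 gives only a limit of the assay and not a number, so the full size of the earlier step remains unknown: the limit of > 50000 nM in this assay, at which 1 of the 4 values shown sits.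

The two cores differ from each other in more than one place, so the compounds shown leave open which of those differences, if any, bears on the size of this step, and two examples of one change are too few to establish a rule for the series. They also leave open how this assay would read for a phenyl carrying a single hydroxyl group, or for a carboxylic acid, in place of the 3,4-dihydroxyphenyl group on either core.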